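Cytotoxicity notes: from compound 1 to compound 3

This account rests on a few compounds, and the source may have more. Where it says the series, first, only, none or still open, it means among the compounds named here.

Measured so far in an ADME assay on MDBK cells (Bos taurus) for cytotoxicity, read by MTT assay, with a stated time of 96 h; on this read-out higher numbers stand for lower toxicity in this test and lower numbers for higher toxicity in this test:
- compound 1 `FC(F)(F)c1cccc(NC(=S)Nc2cccc(Br)c2)c1`: 10000 nM
- compound 2 `Fc1ccc(NC(=S)Nc2cccc(C(F)(F)F)c2)cc1Cl`: 11000 nM

Compound 1 and compound 2 sit within the scatter of each other in this assay, so the two numbers show no difference that can be read as real. Compound 1 is the reference point for the next step.

Compound 3 `FC(F)(F)c1cccc(NC(=S)Nc2ccccc2Br)c1` has not been measured in this assay. It differs from compound 1 in one place: 2-bromophenyl in place of 3-bromophenyl on an amide-type nitrogen. The two compounds share all atoms and differ only in how the bromophenyl group is joined.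

Among the compounds with values here, no pair of measured compounds shows what such a change does in this assay, and the only two numbers available agree with each other. With nothing to point to a move in either direction, the expectation for the step from compound 1 to compound 3 is a change no larger than the scatter, no change at the digits printed from compound 1 to compound 3 (within the scatter).

Compound 3 is therefore estimated at 10000 nM in this assay, with a range from 4000 nM to 25000 nM.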

Compound 3, half-maximal cytotoxic concentration: > 100000 nM
Compound 3 ended at the assay's limit (the forecaster's own chance of this, stated with the estimate: 15%); middle value at least 10-fold (1.00 log units) away from the limit.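

In this assay, compound 3 gives > 100000 nM, which is a limit of the assay and not a number. Compound 1 and compound 2 gave no sign of how far this read-out can move within the series, whereas 2-bromophenyl in place of 3-bromophenyl on an amide-type nitrogen, with no atom gained or lost, gives an at least 10-fold higher number from compound 1 to compound 3 (1.00 log units; beyond the scatter), so in this pair the way the bromophenyl group is joined is enough to shift the result beyond the scatter, towards lower toxicity in this test. The full size of the step cannot be stated because the value of compound 3 rests on a limit: the limit of > 100000 nM in this assay, at which 1 of the 3 values shown sits.

Open, going by these compounds, is whether the step belongs to the bromine itself or would also appear with other groups, such as 2-methoxyphenyl or 2-aminophenyl in place of 2-bromophenyl. Also open, on these data alone, is whether the same change would act alike in a compound with a carboxylic acid in place of the trifluoromethyl group of the shared core.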